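A Larger Group in Place of Fluoro on Compound 2

The source may hold more compounds than are shown below. What is called first, only, known or untested is meant among the compounds shown, and "the series" means these compounds.

In a functional assay on PC9/GR4 cells (Homo sapiens) for antiproliferative activity, read by luminescence, with a stated time of 72 h (on this read-out higher numbers stand for weaker inhibition and lower numbers for stronger inhibition), compound 1 (`NC(=O)Nc1ccc2ncnc(Nc3ccc(F)c(Cl)c3)c2c1`) gives 21700 nM and compound 2 (`CC(=O)Nc1ccc2ncnc(Nc3ccc(F)c(Cl)c3)c2c1`) gives 12600 nM, two values within the scatter of each other. Compound 3 (`CC(=O)Nc1ccc2ncnc(Nc3ccc(OCc4cccc(F)c4)c(Cl)c3)c2c1`) carries (3-fluorobenzyl)oxy in place of fluoro on an aromatic carbon. Among the measured compounds shown here, the only measured step, a 1.7-fold lower number from compound 1 to compound 2 (0.24 log units; within the scatter), lies within the scatter and sits elsewhere on the molecule, so it says little about this change. The expectation therefore starts from compound 2 at 12600 nM and leans modestly towards a lower number, with wide uncertainty. Compound 3 is estimated at 4000 nM, within a range of 1000 nM to 12000 nM. That estimate means an expected 3.2-fold lower number from compound 2 to compound 3 (0.50 log units; beyond the scatter).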

Compound 3, half-maximal inhibitory concentration: 8310 nM
Beside the measured number, compound 3's estimate is 2.1-fold (0.32 log units) below it, and the stated range covers the measured number.
By their numbers in this assay, from the lowest: compounds 3, 2 and 1 (each within the scatter of the next, the first and the last beyond it).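

In this assay, the aromatic carbon ortho to a chloro group takes the much larger (3-fluorobenzyl)oxy in place of fluoro, with a 1.5-fold lower number from compound 2 to compound 3 (0.18 log units; within the scatter). This position therefore accepts an added six-membered aromatic ring and an ether oxygen while the two compounds stay within the scatter of each other, something the earlier pair, which differed elsewhere on the molecule, could not show. Nothing available explains this result.

As far as these compounds go, whether a plain benzyloxy, an amine or a carboxylic acid on this carbon would move the number beyond the scatter remains open.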